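Branching the alkenyl chain of compound 2

The source may report more compounds than this note shows. Statements on the series, on what has been measured and on what is new or still open speak of the compounds shown alone.

In a functional assay on A549 cells (Homo sapiens) for antiproliferative activity, read by MTT assay, with a stated time of 72 h (a lower number here means a stronger inhibitor, a higher number a weaker inhibitor), compound 1 (`C=CC(=O)Nc1cccc(Oc2nc(Nc3ccn(C)n3)nc3c2CSCC3)c1`) gives 18600 nM and compound 3 (`CCC/C=C/C(=O)Nc1cccc(Oc2nc(Nc3ccn(C)n3)nc3c2CSCC3)c1`) gives 8190 nM as measured values. Compound 2 (`C/C=C/C(=O)Nc1cccc(Oc2nc(Nc3ccn(C)n3)nc3c2CSCC3)c1`) reads > 50000 nM as a limit of the assay and not a number. Compound 2 therefore stands on the limit of > 50000 nM in this assay, at which 1 of the 3 values shown sits, and on no measured number.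

Compound 4 (`CC(C)/C=C/C(=O)Nc1cccc(Oc2nc(Nc3ccn(C)n3)nc3c2CSCC3)c1`) departs from compound 2 by isopropyl in place of methyl on a double-bonded chain carbon bound to a double-bonded chain carbon in one place, isopropyl in place of methyl on a double-bonded chain carbon bound to a double-bonded chain carbon. The closest measured change is an at least 6.1-fold lower number from compound 2 to compound 3 (0.78 log units; beyond the scatter) for ethyl in place of hydrogen on a saturated chain carbon bound to a double-bonded chain carbon. The other two steps are an at least 2.6-fold higher number from compound 1 to compound 2 (0.42 log units; beyond the scatter) for prop-1-en-1-yl and a 2.3-fold lower number from compound 1 to compound 3 (0.36 log units; beyond the scatter) for pent-1-en-1-yl, so the three compounds do not move in one direction along the chain. A lower number is thus expected, in the direction of the step to compound 3, though with less certainty. The expected change is an at least 3.1-fold lower number from compound 2 to compound 4 (0.49 log units; beyond the scatter) as an estimate. The estimate for compound 4 is 16000 nM with an expected range from 6000 nM to 45000 nM as its likely span.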

Compound 4, half-maximal inhibitory concentration: 33500 nM
Estimate against measurement, compound 4: 2.1-fold (0.32 log units) below; measured number inside the range.
By their numbers in this assay, from the lowest: compound 3; then compounds 1 and 4 (each within the scatter of the next). At a limit, above all of these: compound 2.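

Branching is what this position newly shows: in this assay, isopropyl in place of propyl on the double-bonded chain carbon gives a 4.1-fold higher number from compound 3 to compound 4 (0.61 log units; beyond the scatter), so the gain seen with the straight pent-1-en-1-yl chain does not carry over to the branched chain, and 3-methylbut-1-en-1-yl in place of vinyl gives only a 1.8-fold higher number from compound 1 to compound 4 (0.26 log units; within the scatter). Isopropyl in place of methyl gives an at least 1.4-fold lower number from compound 2 to compound 4 (0.17 log units; that floor lies within the scatter), which does not establish a real gain over methyl. Compound 2 is held only by a limit, so this step has a floor and no measured size: the limit of > 50000 nM in this assay, at which 1 of the 4 values shown sits.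

The compounds shown leave open whether a longer straight chain than propyl would lower the number further at this place. They also leave open how a cyclopropyl ring or a dimethylamino group there would compare with propyl and isopropyl.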